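A few compounds are considered here, and "the series" means these few. Any claim that something is new, unique, unknown or untested is made for them only; others in the source may bear on it.

Measured compounds:
- compound 1 `COc1cccc(/C(C)=C/CN(C)Cc2ccccc2)c1`, which in an assay on cell membranes for displacement of a labelled ligand from Sigma non-opioid intracellular receptor 1 (Cavia porcellus), read by scintillation counting, with a stated time of 150 min (on this read-out lower numbers stand for stronger inhibition and higher numbers for weaker inhibition), gives 10 nM
- compound 2 `C/C(=C\CN1CCCCC1)c1ccccc1`, which in this assay gives 459 nM
- compound 3 `COc1cccc(/C(C)=C/CN(C)C)c1`, for which this assay reports only a limit

For compound 3 the read-out in this assay is > 1000 nM, which is a limit of the assay and not a number (the limit of > 1000 nM in this assay, at which 1 of the 3 values shown sits). Compound 3 therefore stands at the weak end of the values shown, with no exact figure. Compound 4 `COc1cccc(/C(C)=C/CN2CCCCC2)c1` differs from compound 3 by piperidin-1-yl in place of dimethylamino on a saturated chain carbon bound to a double-bonded chain carbon. Within the data shown here, no measured step makes exactly this change. The step of an at least 100-fold higher number from compound 1 to compound 3 (2.00 log units; beyond the scatter) bears on it in reverse: putting a larger group onto the amine nitrogen of compound 3 went along with a much lower number in compound 1. Compound 2, which carries the same piperidin-1-yl group, gives 459 nM in this assay. On this basis compound 4 is expected to show a step of an at least 2.5-fold lower number from compound 3 to compound 4 (0.39 log units; beyond the scatter) toward a lower number. Compound 4 is estimated at 400 nM, with a range from 100 nM to 1500 nM.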

Compound 4, inhibition constant: 91 nM
Estimate against measurement, compound 4: 4.4-fold (0.64 log units) above, and the stated range ends above it.
By their numbers in this assay, from the lowest: compound 1; then compound 4; then compound 2. At a limit, above all of these: compound 3.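

In this assay, piperidin-1-yl in place of dimethylamino on a saturated chain carbon bound to a double-bonded chain carbon gives a clear gain (an at least 10-fold lower number from compound 3 to compound 4 (1.04 log units; beyond the scatter)), so the number at this position can fall without the phenyl group that compound 1 carries. The read-out for compound 3 is a limit of the assay and not a number: the limit of > 1000 nM in this assay, at which 1 of the 4 values shown sits. Among these compounds, the aromatic ring also counts, with the amine end held fixed: methoxy in place of hydrogen on an aromatic carbon gives a smaller but real gain (a 5.0-fold lower number from compound 2 to compound 4 (0.70 log units; beyond the scatter)), which the earlier compounds could not isolate.

From the compounds shown here alone, what a pyrrolidine or a morpholine would give at the same chain carbon stays open. So does whether a hydroxy group or a fluorine in place of the methoxy would keep that gain.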